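Side-chain change from compound 2 to compound 3

The compounds below may be only part of what the source reports. "The series", "measured", "known", "first", "only" and "open" are said of these compounds alone.

Measured in a physicochemical assay for solubility, read by nephelometry, measured as kinetic solubility, with a stated time of 30 min; on this read-out lower numbers stand for lower solubility and higher numbers for higher solubility:
- compound 1 `CC(C)(N)CCOc1ccc([C@H]2CC[C@]3(CC2)OOC2(O3)C3CC4CC(C3)CC2C4)cc1`: 50 ug/mL
- compound 2 `NCCCCOc1ccc([C@H]2CC[C@]3(CC2)OOC2(O3)C3CC4CC(C3)CC2C4)cc1`: 50 ug/mL

Level with compound 1, compound 2 stands at 50 ug/mL in this assay. The next compound is compound 3 `CC1(C)CC(O)(COc2ccc([C@H]3CC[C@]4(CC3)OOC3(O4)C4CC5CC(C4)CC3C5)cc2)CC(C)(C)N1`, and the change is 4-hydroxy-2,2,6,6-tetramethylpiperidin-4-yl in place of 3-aminopropyl on a saturated chain carbon bound to an oxygen on an aromatic ring. In words, 4-hydroxy-2,2,6,6-tetramethylpiperidin-4-yl comes in place of 3-aminopropyl on a saturated chain carbon bound to an oxygen on an aromatic ring.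

Within the data shown here, only one measured step bears on this: no change at the digits printed from compound 1 to compound 2 (within the scatter), which exchanged 1-amino-1-methylethyl for 2-aminoethyl. That evidence is thin. Among the measured compounds shown here, it is a single step between two open-chain groups, and no measured compound carries a ring in this part of the side chain. The data therefore give no direction for the new change, and a step beyond the scatter in this assay is not expected from them. The expected step is no change at the digits printed from compound 2 to compound 3 (within the scatter), held with a wide margin on both sides. For compound 3 the estimated value is 50 ug/mL, with an expected range of 20 ug/mL to 100 ug/mL.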

Compound 3, solubility: > 100 ug/mL
Compound 3 ended at the assay's limit; the forecaster's own chance of this, stated with the estimate: 10%; at least 2.0-fold (0.30 log units) between middle value and limit.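

In this assay compound 3 reads > 100 ug/mL, which is a limit of the assay and not a number: the limit of > 100 ug/mL in this assay, at which 1 of the 3 values shown sits.

Set against the two open-chain amines, the change gives an at least 2.0-fold higher number from compound 2 to compound 3 (0.30 log units; that floor lies within the scatter) and an at least 2.0-fold higher number from compound 1 to compound 3 (0.30 log units; that floor lies within the scatter) in this assay, so only a floor is known for each step and their true sizes stay unread. Where the earlier step exchanged one open-chain group for another, this position on a saturated chain carbon bound to an oxygen on an aromatic ring now carries a 4-hydroxy-2,2,6,6-tetramethylpiperidin-4-yl group, with 11 heavy atoms against 4 for 3-aminopropyl, and the reading still ends at the top of the assay's range.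

The ring, the hydroxy group and the four methyl groups enter together, so their separate contributions cannot be told apart, and a plain piperidin-4-yl or a 4-hydroxypiperidin-4-yl without the methyl groups would be needed to divide them. On these data alone, how a side chain ending in a carboxylic acid, or a longer chain carrying the same amine, would read at this position also remains open.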